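A few compounds are considered here, and "the series" means these few. Any claim that something is new, unique, unknown or untested is made for them only; others in the source may bear on it.

Three compounds built on one shared core were tested in a functional assay on SUP-B15 cells (Homo sapiens) for antiproliferative activity, with a stated time of 72 h; a higher number here means that more compound is needed for the effect, a lower number that less compound is needed. Compound 3 `COc1ccc(-c2cc(=O)c3c(OC)cc(OC)cc3n2S(=O)(=O)c2ccc(Cl)cc2)cc1` gives in this assay only a limit of > 34400 nM, not a measured number. Compound 1 `COc1ccc(-c2cc(=O)c3c(OC)cc(OC)cc3n2S(=O)(=O)c2cccc([N+](=O)[O-])c2)cc1` gives in this assay likewise only a limit, > 39600 nM. Compound 2 `COc1ccc(-c2cc(=O)c3c(OC)cc(OC)cc3n2S(=O)(=O)c2ccc(F)cc2)cc1` gives in this assay also only a limit, > 65500 nM. As far as these compounds go, with every result a limit, the steps between the three cannot be read in size: a step that the two limits leave unreadable from compound 1 to compound 2, a step that the two limits leave unreadable from compound 1 to compound 3 and a step that the two limits leave unreadable from compound 2 to compound 3 all remain open. Compound 3 thus stands at one of three unreadable positions, marked by the limit of > 34400 nM in this assay, at which 1 of the 3 values shown sits.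

Compound 4 `COc1ccc(-c2cc(=O)c3c(OC)cc(OC)cc3n2S(=O)(=O)c2cc(Cl)cc(Cl)c2O)cc1` differs from compound 3 in one place: 3,5-dichloro-2-hydroxyphenyl in place of 4-chlorophenyl on a sulfonyl sulfur. Going by the values given here, none of the measured steps bears readably on this change, as each connects two limits. The step from compound 3 to compound 4 is therefore expected to be roughly a step that the limit leaves unreadable from compound 3 to compound 4, a guess with little support. Compound 4 is estimated to give about 40000 nM in this assay, within a range from 10000 nM to 120000 nM, with a real chance that again only a limit is reported.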

Compound 4, half-maximal effective concentration: > 37900 nM
Compound 4: only a limit was reported; the forecaster's own chance of this, stated with the estimate: 65%; the middle value is on the limit's open side.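

In this assay, going by these compounds alone, compound 4 gives only a limit, as do compound 1, compound 2 and compound 3, so no step between compound 4 and the other three can be read. The compounds shown leave open whether the group on the sulfonyl sulfur changes antiproliferative activity at all.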